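From Dichlorophenyl to Bromophenyl in Compound 2

The source may report more compounds than this note shows. Statements on the series, on what has been measured and on what is new or still open speak of the compounds shown alone.

In a functional assay on K562/Adr cells (Homo sapiens) for inhibition, read by MTT assay, with a stated time of 48 h (a lower number here means a stronger inhibitor, a higher number a weaker inhibitor), compound 1 (`O=C(NC1CC1)c1cncc(-c2cn([C@@H]3CN[C@H](C(=O)Nc4ccc(Cl)c(C(F)(F)F)c4)C3)nn2)c1`) gives 175000 nM and compound 2 (`CC(=O)Nc1n[nH]c2cc(-c3cn([C@@H]4CN[C@H](C(=O)Nc5ccc(Cl)cc5Cl)C4)nn3)ccc12`) gives 1230 nM as the lower of the two numbers, a gap well beyond the scatter of repeated measurements. These two compounds differ in more than one place, so their gap does not isolate any single change. Compound 3 (`CC(=O)Nc1n[nH]c2cc(-c3cn([C@@H]4CN[C@H](C(=O)Nc5ccc(Br)cc5)C4)nn3)ccc12`) matches compound 2 except for one group, with 4-bromophenyl in place of 2,4-dichlorophenyl on an amide-type nitrogen. Among the measured compounds shown here, no measured pair tests this swap, so the expectation is only a small weakening that may stay within the scatter. The estimated change is a 1.6-fold higher number from compound 2 to compound 3 (0.21 log units; within the scatter) in this assay and is expected to be far smaller than the gap between the two measured compounds. For compound 3 the estimated value is 2000 nM (with a range from 500 nM to 8000 nM).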

Compound 3, half-maximal inhibitory concentration: 1000 nM
Compound 3: the middle estimate sits 2.0-fold (0.30 log units) above what was measured, and the stated range covers the measured number.
By their numbers in this assay, from the lowest: compounds 3 and 2 (each within the scatter of the next); then compound 1.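

In this assay, putting 4-bromophenyl in place of 2,4-dichlorophenyl on the amide-type nitrogen gives a 1.2-fold lower number from compound 2 to compound 3 (0.09 log units; within the scatter) and so leaves the two compounds indistinguishable. Among the compounds shown here, this is the first comparison here that isolates a single change, and it shows that this position can carry either ring, with one bromine or two chlorines, without a reading outside the scatter. Nothing measured here explains this tolerance.

Still open, from the compounds shown here alone, is whether the position holds up with a different kind of group, such as an unsubstituted phenyl, a pyridine ring, or a phenyl ring bearing an amine or a carboxylic acid. The gap between compound 1 and the other two compounds also remains unassigned, as compound 1 differs from them in more than one place.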